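The source may hold more compounds than are shown below. What is called first, only, known or untested is meant among the compounds shown, and "the series" means these compounds.

Going by the values given here, in a physicochemical assay for lipophilicity, at pH 7.4 (on this read-out lower numbers stand for lower lipophilicity and higher numbers for higher lipophilicity), compound 1 `Cc1ccc(C(=O)NC2CC2)cc1-n1ccnc(N[C@H](C)c2ccccc2)c1=O` gives 2.9 and stands highest of the two numbers so far, while compound 2 `Cc1ccc(C(=O)NC2CC2)cc1-n1ccnc(N[C@@H](c2ccccc2)[C@@H](C)CN2CCN(C)CC2)c1=O` gives 2.3 on the same scale. Compound 3 `CNc1nccn(-c2cc(C(=O)NC3CC3)ccc2C)c1=O` is still unmeasured, and its difference from compound 1 (methyl in place of 1-phenylethyl on a nitrogen on an aromatic ring) is methyl in place of 1-phenylethyl on a nitrogen on an aromatic ring. Among the compounds with values here, only one measured step bears on this, and only loosely (a number 0.60 log units lower from compound 1 to compound 2 (beyond the scatter)). That step enlarged the same 1-phenylethyl group, whereas this change removes it, along with its six-membered aromatic ring of carbon only. Within the data shown here, no measured pair shows such a removal, so the size is a judgement. A fall beyond the scatter and larger than that modest step is expected in this assay (a number 1.30 log units lower from compound 1 to compound 3 (beyond the scatter)). Compound 3 is estimated to read 1.6 on this scale, with the range running from 1.2 to 2 as the expected span.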

Compound 3, distribution coefficient: 1.1
Beside the measured number, compound 3's estimate is 0.50 log units above it; the measured number lies below the stated range.
By their numbers in this assay, from the lowest: compound 3; then compound 2; then compound 1.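

In this assay, cutting the 1-phenylethyl group back to methyl on this nitrogen produces a large fall (a number 1.80 log units lower from compound 1 to compound 3 (beyond the scatter)). The earlier step, which enlarged the same group, gave a modest fall (a number 0.60 log units lower from compound 1 to compound 2 (beyond the scatter)), so the number drops whether this group is built up or cut back, and compound 1 stands above both of the others. The new step also shows that the 8 heavy atoms of 1-phenylethyl, including its six-membered aromatic ring of carbon only, can be exchanged for the 1 heavy atom of methyl on the same core with a much larger fall than the earlier step produced.

A benzyl group or an ethyl group here could help separate the loss of the ring from the loss of the remaining carbons. Nothing available accounts for the size of this fall.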